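The source may hold more compounds than are shown below. What is called first, only, known or untested is meant among the compounds shown, and "the series" means these compounds.

Compound 1 has the structure `CN(Cc1ccc(I)cc1)CC1C[C@H]2CC[C@]1(C)C2(C)C`; in an assay on HEK293 cells for displacement of a labelled ligand from C-X-C chemokine receptor type 3 (Homo sapiens) (a higher number here means a weaker inhibitor, a lower number a stronger inhibitor), compound 1 gives 7940 nM.
Compound 2 has the structure `CN(CC1=CC[C@H]2C[C@@H]1C2(C)C)Cc1cccc(I)c1`; in this assay compound 2 gives 7940 nM.
Compound 3 has the structure `CN(CC1=CC[C@H]2C[C@@H]1C2(C)C)Cc1ccc(-c2ccccc2F)cc1`; in this assay compound 3 gives only a limit, > 316 nM.

Compound 1 and compound 2 fall within the usual scatter of each other, so no difference between them can be claimed. Compound 3 stands apart from them in kind rather than in degree: for compound 3 only a limit is known, which is the limit of > 316 nM in this assay, at which 1 of the 3 values shown sits, and no single number can be placed against it. Where compound 3 truly sits below that limit therefore stays open.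

Compound 4, with the structure `CN(CC1=CC[C@H]2C[C@@H]1C2(C)C)Cc1ccc(-c2cccc([N+](=O)[O-])c2)cc1`, has not yet been measured in this assay. It differs from compound 3 in one place: 3-nitrophenyl in place of 2-fluorophenyl on an aromatic carbon. Among the compounds with values here, no measured pair in this set shows what such a change does, so nothing here says in which direction it will move the binding, nor by how much. Given that compound 3 gives only a limit, compound 4 is expected to land in the same weak region, with the step from compound 3 to compound 4 estimated as a step that the limit leaves unreadable from compound 3 to compound 4. Compound 4 is therefore estimated at 3000 nM, within a range from 500 nM to 20000 nM.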

Compound 4, inhibition constant: 2000 nM
Compound 4: the middle estimate sits 1.5-fold (0.18 log units) above what was measured; low and high end bracket the measured number.
By their numbers in this assay, from the lowest: compound 4; then compounds 1 and 2 (each within the scatter of the next).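

No step can be read between compound 3 and compound 4, neither its size nor its direction, because compound 3 is known only through a limit: the limit of > 316 nM in this assay, at which 1 of the 4 values shown sits.

The compounds shown leave open whether 3-nitrophenyl in place of 2-fluorophenyl strengthens or weakens binding in this assay and where compound 3 truly sits.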